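The source may hold more compounds than are shown below. What is called first, only, known or untested is meant among the compounds shown, and "the series" means these compounds.

Measured in a toxicity assay on NIH3T3 cells (Mus musculus) for cytotoxicity, read by resazurin assay; a higher number here means that more compound is needed for the effect, a lower number that less compound is needed:
- compound 1 `COC(=O)c1ccc(NCc2cncn2Cc2ccc(Cl)cc2)cc1-c1ccccc1`: 25000 nM
- compound 2 `Clc1ccc(NCc2cncn2Cc2ccc(-c3ccccc3)cc2)cc1-c1ccccc1`: > 1000 nM (a limit of the assay, not a number)

For the measured compounds named here, compound 1 holds the only actual number, so its position cannot be ranked against a second measured value. In this assay compound 2 is recorded only as a limit, > 1000 nM.

The next compound is compound 3 `COC(=O)c1ccc(NCc2cncn2Cc2ccccc2)cc1-c1ccccc1`, which has hydrogen in place of chloro on an aromatic carbon, para to a large group (hydrogen in place of chloro on an aromatic carbon). The same difference reads 4-chlorobenzyl to benzyl, and the rest of the structure of compound 1 stays unchanged.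

Going by the values given here, no measured pair shows what this change does, so the expectation rests on compound 1 at 25000 nM and on the modest size of the edit. The expected change a 1.2-fold higher number from compound 1 to compound 3 (0.08 log units; within the scatter) is none beyond the usual scatter of this assay, with at most a slight drift toward higher numbers. The estimated value for compound 3 is 30000 nM, with an expected range from 10000 nM to 80000 nM.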

Compound 3, half-maximal effective concentration: > 1000 nM
Compound 3 ended at the assay's limit; the forecaster's own chance of this, stated with the estimate: 35%; the middle value is on the limit's open side.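

In this assay, for the compounds shown here, compound 3 is recorded only as a limit, > 1000 nM, and not as a number, so no step from compound 1 to compound 3 can be read. Most of the series sits at this limit: the limit of > 1000 nM in this assay, at which 2 of the 3 values shown sit. From the compounds shown here alone, whether the change from 4-chlorobenzyl to benzyl shifts the value at all, and in which direction, stays open.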